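Aryl replacement on the shared core: a thiazole analogue

This account rests on a few compounds, and the source may have more. Where it says the series, first, only, none or still open, it means among the compounds named here.

Compound 1 `c1cnc(-c2ccccc2OCC2=NCCN2)nc1`: < 100000 nM
Compound 2 `c1coc(-c2ccccc2OCC2=NCCN2)c1`: 10 nM
Compound 3 `Cc1csc(-c2ccccc2OCC2=NCCN2)n1`: to be measured

In a functional assay for activation of Alpha-1B adrenergic receptor (Homo sapiens), read by calcium flux (a higher number here means that more compound is needed for the effect, a lower number that less compound is needed), compound 1 gives < 100000 nM, a limit of the assay rather than a number (the limit of < 100000 nM in this assay, at which 1 of the 2 values shown sits). Compound 2 gives 10 nM. The step that the limit leaves unreadable from compound 1 to compound 2 is therefore of unreadable size. Compound 3 carries 4-methyl-1,3-thiazol-2-yl in place of pyrimidin-2-yl on an aromatic carbon. Among the measured compounds shown here, the single step that bears on this change, the one to compound 2, also exchanges pyrimidin-2-yl for a five-membered aromatic ring with hetero atoms, and the limit hides how large it is; it points toward a measurable value. Compound 3 is expected to show a step that the limit leaves unreadable from compound 1 to compound 3. For compound 3 the estimated value in this assay is 30 nM, with a range from 5 nM to 400 nM.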

Compound 3, half-maximal effective concentration: < 100000 nM
Compound 3 ended at the assay's limit; the forecaster's own chance of this, stated with the estimate: 10%; the middle value does not contradict the limit.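

No new step can be read from compound 3 to compound 1 or compound 2, as compound 3 stands at a limit of the assay. The compounds shown leave open how far 4-methyl-1,3-thiazol-2-yl lies from furan-2-yl in activity.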